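This account rests on a few compounds, and the source may have more. Where it says the series, first, only, none or still open, it means among the compounds named here.

Measured compounds:
compound 1 `Cc1nnc(Sc2cc(NS(=O)(=O)c3ccc([N+](=O)[O-])cc3)ccc2O)s1`: 14.3%
compound 2 `O=C(Nc1ccc(O)c(Sc2nncs2)c1)c1ccc([N+](=O)[O-])cc1`: "not active" (no number reported)

Going by the values given here, in an assay on isolated protein for inhibition of RAC-alpha serine/threonine-protein kinase (Homo sapiens), read by fluorescence, with a stated time of 30 min, tested at 10 uM (on this read-out higher numbers stand for more inhibition at the one concentration tested (going by the name of the read-out) and lower numbers for less inhibition), compound 1 gives 14.3%, which is the only number in this set. Compound 2 is recorded there as "not active" (no number reported), without a figure. Compound 1 therefore stands alone as the single measured reference point. Compound 3 `Cn1nnnc1Sc1cc(NS(=O)(=O)c2ccc([N+](=O)[O-])cc2)ccc1O` is not yet measured; it differs from compound 1 by 1-methyl-1H-tetrazol-5-yl in place of 5-methyl-1,3,4-thiadiazol-2-yl on a sulfur. Among the compounds with values here, with no measured step of this kind to lean on, only a change within the usual scatter is expected, in no particular direction. The expected step of a number 1.3 percentage points lower from compound 1 to compound 3 (within the scatter) is small. Compound 3 is expected to give 13%, between 0% and 30%.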

Compound 3, a percentage reported as inhibition, at one concentration (the size of the read-out at that concentration, not a potency): 11.5%
Estimate against measurement, compound 3: 1.5 percentage points above; measured number inside the range.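

Putting 1-methyl-1H-tetrazol-5-yl in place of 5-methyl-1,3,4-thiadiazol-2-yl on the sulfur gives a number 2.8 percentage points lower from compound 1 to compound 3 (within the scatter) in this assay. Going by these compounds alone, this is the only measured step at this position, and it shows that these two five-membered aromatic rings cannot be told apart on this read-out. Nothing measured here bears on the reason for this result.

Still open, going by these compounds, is whether a quite different group on that sulfur, such as a carboxylic acid or a longer alkyl chain, would move the number beyond the usual scatter. Changes elsewhere on the shared core also remain open.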